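This account rests on a few compounds, and the source may have more. Where it says the series, first, only, none or still open, it means among the compounds named here.

In a functional assay on HeLa cells (Homo sapiens) for cytotoxicity, read by MTT assay, with a stated time of 72 h (on this read-out lower numbers stand for stronger inhibition and higher numbers for weaker inhibition), compound 1 (`COc1ccc(Nc2cc(-c3cccc(C(F)(F)F)c3)ccn2)cc1`) gives 140000 nM as a measured number. Compound 2 (`CCc1ccc(Nc2cc(-c3cccc(C(F)(F)F)c3)ccn2)cc1`) gives > 200000 nM as a limit of the assay and not as a number. Compound 2 therefore stands at the limit of > 200000 nM in this assay, at which 1 of the 2 values shown sits, and has no exact place on the scale. Compound 3 (`COc1cccc(Nc2cc(-c3cccc(C(F)(F)F)c3)ccn2)c1`) has not yet been measured, and the change leading to it is 3-methoxyphenyl in place of 4-ethylphenyl on a nitrogen on an aromatic ring with 3-methoxyphenyl in place of 4-ethylphenyl on a nitrogen on an aromatic ring. Among the measured compounds shown here, only one measured step bears on this change, namely an at least 1.4-fold higher number from compound 1 to compound 2 (0.15 log units; that floor lies within the scatter) for ethyl in place of methoxy on an aromatic carbon. Read in reverse, it suggests only a modest move to a lower number in this assay for compound 3. Like compound 3, compound 1 carries a methoxy group, and its 140000 nM anchors the expectation. The expected change is an at least 1.5-fold lower number from compound 2 to compound 3 (0.18 log units; that floor lies within the scatter) in this estimate. For compound 3 the estimated value is 130000 nM with an expected range from 50000 nM to 200000 nM as its span.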

Compound 3, half-maximal inhibitory concentration: > 200000 nM
Compound 3: a limit, no number; the forecaster's own chance of this, stated with the estimate: 35%; middle value at least 1.5-fold (0.18 log units) away from the limit.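

Like compound 1, compound 3 carries a methoxy group, yet in this assay compound 3 gives > 200000 nM, which is a limit and not a number. With the 3-methoxyphenyl group instead of the 4-methoxyphenyl group, the methoxy group no longer goes with a measured number: the change gives an at least 1.4-fold higher number from compound 1 to compound 3 (0.15 log units; that floor lies within the scatter), and the step between the two limits cannot be read. The two compounds at the limit therefore have no order between them on this scale: the limit of > 200000 nM in this assay, at which 2 of the 3 values shown sit.

Going by these compounds, how far past the limit compound 2 and compound 3 lie stays open, and so does whether the change from the 4-methoxyphenyl group truly exceeds the scatter. Also open, on these data alone, is how an amine or a carboxylic acid on that phenyl ring would read in this assay.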